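The source may hold more compounds than are shown below. What is called first, only, known or untested is meant among the compounds shown, and "the series" means these compounds.

Working notes on the sulfonylurea series. Going by the values given here, in an assay on liver for inhibition of sterol O-acyltransferase 1 (Rattus norvegicus), using microsomes (on this read-out lower numbers stand for stronger inhibition and higher numbers for weaker inhibition), compound 1 `CC(C)c1cccc(C(C)C)c1NC(=O)NS(=O)(=O)N(C)C` gives 3900 nM, which is the second highest of the three numbers so far. Compound 2 `CCCCCCCCCCCCCCCCCCN(C)S(=O)(=O)NC(=O)Nc1c(C(C)C)cccc1C(C)C`, carrying a long chain on the sulfamide nitrogen, gives 1900 nM in this assay, a number beyond the scatter from that of compound 1. Compound 3 `CC(C)c1cccc(C(C)C)c1NS(=O)(=O)NC(=O)NC(c1ccccc1)c1ccccc1`, with a diphenylmethyl group on the urea, gives 30000 nM and sits furthest from compound 1, the widest gap in the set. Among the compounds with values here, no single-point steps between measured compounds are available, so the direction of any change is read only from these three numbers.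

Compound 4 `CCCCCCC(C)OS(=O)(=O)NC(=O)Nc1c(C(C)C)cccc1C(C)C` is not yet measured. It differs from compound 1 in one place: (1-methylheptyl)oxy in place of dimethylamino on a sulfonyl sulfur. Within the data shown here, a long chain entering in place of a small group is the only resemblance to compound 2, and its value 1900 nM is the sole hint of direction. The step from compound 1 to compound 4 is therefore expected to be a modest decrease, a 1.8-fold lower number from compound 1 to compound 4 (0.25 log units; within the scatter), close to the edge of the scatter. Compound 4 is estimated at 2200 nM, within a range of 600 nM to 8000 nM.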

Compound 4, half-maximal inhibitory concentration: 35000 nM
For compound 4 the middle estimate is 16-fold (1.20 log units) below the measured one; the whole stated range lies below it.
By their numbers in this assay, from the lowest: compound 2; then compound 1; then compounds 3 and 4 (each within the scatter of the next).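

In this assay this place on the sulfonyl sulfur proves sensitive to the exchange, with a 9.0-fold higher number from compound 1 to compound 4 (0.95 log units; beyond the scatter) when (1-methylheptyl)oxy enters in place of dimethylamino, so the direction runs towards weaker inhibition. A long chain on this part of the molecule therefore does not go with a lower number in every case: compound 2, with its chain on the sulfamide nitrogen, gives 1900 nM in this read-out, whereas compound 4, with its chain attached through oxygen, gives 35000 nM in the same read-out. The exchange alters both the attaching atom and the size of the group, and no measurement shown here accounts for the step.

As far as these compounds go, it remains open whether a small methoxy group on this sulfur would stay near compound 1 or move towards compound 4. An unbranched octyloxy group, or a 1-methylheptylamino group, would help separate the effect of the branched chain from that of the attaching oxygen.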